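Chloro for methyl on the core of compound 1

The source may hold more compounds than are shown below. What is called first, only, known or untested is meant among the compounds shown, and "the series" means these compounds.

Measured so far in an assay for inhibition of Thromboxane-A synthase (Homo sapiens); on this read-out lower numbers stand for stronger inhibition and higher numbers for weaker inhibition:
compound 1 `Cc1c(Cn2ccnc2)sc2cc(C(=O)O)ccc12` gives 18 nM
compound 2 `Cc1c(Cn2ccnc2)[nH]c2ccc(C(=O)O)cc12` gives 37 nM
compound 3 `O=C(O)c1ccc2sc(Cn3ccnc3)cc2c1` gives 15 nM

Compound 1 stands second highest of the three numbers. Its nearest neighbour is compound 3, whose number is lower by a margin that falls within the scatter, so the two cannot be ordered. Compound 2 sits furthest away, with a higher number, and that gap lies beyond the scatter.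

Compound 4 `O=C(O)c1ccc2c(Cl)c(Cn3ccnc3)sc2c1` differs from compound 1 by chloro in place of methyl on an aromatic carbon. Within the data shown here, no measured pair in this small set carries this exchange, so no step size can be read from the data; the nearby measured pairs show only modest spreads.

The step of a 1.1-fold higher number from compound 1 to compound 4 (0.05 log units; within the scatter) is expected to stay within the scatter, with no clear direction. Compound 4 is expected to give 20 nM, estimated between 8 nM and 50 nM.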

Compound 4, half-maximal inhibitory concentration: 40 nM
Beside the measured number, compound 4's estimate is 2.0-fold (0.30 log units) below it; low and high end bracket the measured number.
By their numbers in this assay, from the lowest: compounds 3 and 1 (each within the scatter of the next); then compounds 2 and 4 (each within the scatter of the next).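

In this assay, the position next to the ring atom that bears the (1H-imidazol-1-yl)methyl group responds to this exchange: chloro in place of methyl gives a 2.2-fold higher number from compound 1 to compound 4 (0.35 log units; beyond the scatter) as the only single-place step shown. Its direction is toward weaker inhibition, and its size is modest but beyond the scatter. No measurement at hand explains this shift.

As far as these compounds go, whether methoxy or fluoro at this position would behave more like methyl or chloro remains open. So does whether the same exchange would give a similar step on the core of compound 2.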